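Methyl for Chloro on the Benzyl at the Assay Ceiling

A few compounds are considered here, and "the series" means these few. Any claim that something is new, unique, unknown or untested is made for them only; others in the source may bear on it.

Compound 2 `Cc1ccc(Nc2nc(SCc3cn(Cc4ccc(Cl)cc4)nn3)nc(-c3ccccc3)c2C#N)cc1` is one of three close analogues examined in a functional assay on MCF7 cells (Homo sapiens) for inhibition, read by MTT assay, with a stated time of 72 h; on this read-out lower numbers stand for stronger inhibition and higher numbers for weaker inhibition. In this assay compound 2 gives only a limit, > 64000 nM. Compound 1 `Cc1ccccc1Nc1nc(SCc2cn(Cc3ccc(Cl)cc3)nn2)nc(-c2ccccc2)c1C#N` likewise gives only a limit in this assay, > 64000 nM. Compound 3 `N#Cc1c(Nc2ccccc2F)nc(SCc2cn(Cc3ccc(Cl)cc3)nn2)nc1-c1ccccc1` also gives only a limit in this assay, > 64000 nM. The steps a step that the two limits leave unreadable from compound 1 to compound 2, a step that the two limits leave unreadable from compound 1 to compound 3 and a step that the two limits leave unreadable from compound 2 to compound 3 therefore cannot be read, since (the limit of > 64000 nM in this assay, at which 3 of the 3 values shown sit). Compound 4 `Cc1ccc(Cn2cc(CSc3nc(Nc4ccc(C)cc4)c(C#N)c(-c4ccccc4)n3)nn2)cc1` differs from compound 2 by methyl in place of chloro on an aromatic carbon, para to a large group on a six-membered aromatic ring of carbon only; cut one bond further out, the change reads 4-chlorobenzyl to 4-methylbenzyl. Going by the values given here, no measured step bears directly on this change: the three measured steps alter the aryl on the nitrogen, not the benzyl, and none of them has a readable size. With every neighbour sitting at the limit, compound 4 is expected to remain at the limit as well, an expected step that the limit leaves unreadable from compound 2 to compound 4 that cannot be told from none. The estimate for compound 4 is 80000 nM, with a range from 30000 nM to 300000 nM, most probably reported again as a limit.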

Compound 4, half-maximal inhibitory concentration: > 64000 nM
Compound 4: only a limit was reported; the forecaster's own chance of this, stated with the estimate: 85%; the middle value does not contradict the limit.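

Compound 2 and compound 4 each give only a limit in this assay, so no step between them can be read: the limit of > 64000 nM in this assay, at which 4 of the 4 values shown sit.

The compounds shown leave open how strongly any of them inhibits, and whether 4-chlorobenzyl or 4-methylbenzyl makes any difference to the read-out.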